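From compound 1 to compound 4

The source may report more compounds than this note shows. Statements on the series, on what has been measured and on what is new or still open speak of the compounds shown alone.

Compound 1 `O=C(Nc1cccc(-n2cc(-c3ccncc3)c(-c3ccc(Cl)c(O)c3)n2)c1)Nc1ccc(Cl)c(Cl)c1`: > 32500 nM, a limit of the assay.
Compound 2 `COc1cc(-c2nn(-c3cccc(NC(=O)c4ccc(Cl)c(C(F)(F)F)c4)c3)cc2-c2ccncc2)ccc1Cl`: > 32500 nM, a limit of the assay.
Compound 3 `COc1cc(-c2nn(-c3cccc(NC(=O)c4ccccc4)c3)cc2-c2ccncc2)ccc1Cl`: > 100000 nM, a limit of the assay.

In a functional assay on Malme-3M cells (Homo sapiens) for inhibition, read by sulforhodamine B assay, with a stated time of 48 h (on this read-out lower numbers stand for higher toxicity in this test and higher numbers for lower toxicity in this test), compound 1 gives only a limit. Every value shown in this assay is a limit: two sit at the limit of > 32500 nM in this assay, at which 2 of the 3 values shown sit, and one sits at the limit of > 100000 nM in this assay, at which 1 of the 3 values shown sits. Going by the values given here, the one computed step, a step that the two limits leave unreadable from compound 2 to compound 3, lies between two limits, concerns the group on the carbonyl carbon rather than the amide-type nitrogen, and gives no readable size.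

Compound 4 `O=C(Nc1cccc(-n2cc(-c3ccncc3)c(-c3ccc(Cl)c(O)c3)n2)c1)Nc1cccc(C(F)(F)F)c1` differs from compound 1 by 3-(trifluoromethyl)phenyl in place of 3,4-dichlorophenyl on an amide-type nitrogen. Among the compounds with values here, no measured step bears on this position, and the measured steps that exist read only as limits. Compound 4 is therefore expected to return a limit again in this assay, with no step beyond the scatter. The expected step that the limit leaves unreadable from compound 1 to compound 4 is taken as flat. The estimate for compound 4 is 50000 nM. Its expected range runs from 20000 nM to 150000 nM.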

Compound 4, concentration lethal to 50% of the cells: > 32500 nM
Compound 4: only a limit was reported; the forecaster's own chance of this, stated with the estimate: 85%; the middle value is on the limit's open side.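

Compound 1 and compound 4 both give only a limit of the assay in this assay, so no step between them can be read: the limit of > 32500 nM in this assay, at which 3 of the 4 values shown sit.

The compounds shown leave open where any true value lies, and whether the group on the amide-type nitrogen affects this read-out at all.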